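Series notes: halogen change on the benzyl arm

The source may report more compounds than this note shows. Statements on the series, on what has been measured and on what is new or still open speak of the compounds shown alone.

Compound 1 `Nc1cc(N)c2nc(-c3ccccc3)c(NCc3ccc(Cl)c(Cl)c3)nc2c1` anchors the set. In a functional assay on SW-620 cells (Homo sapiens) for inhibition, read by sulforhodamine B assay, with a stated time of 48 h (a lower number here means a stronger inhibitor of growth, a higher number a weaker inhibitor of growth), compound 1 gives 3240 nM, the lowest of the three numbers in hand. Compound 2 `CCOC(=O)[C@H](CCC(=O)O)NC(=O)c1ccc(Sc2nc3cc(N)cc(N)c3nc2-c2ccccc2)cc1` gives 11700 nM and compound 3 `CCOC(=O)[C@H](CCC(=O)O)NC(=O)c1ccc(Oc2nc3cc(N)cc(N)c3nc2-c2ccccc2)cc1` gives 29500 nM in this assay; both lie beyond the scatter from compound 1, compound 3 furthest. Compound 4 `Nc1cc(N)c2nc(-c3ccccc3)c(NCc3ccc(F)cc3)nc2c1` has not been measured. It differs from compound 1 in one place: 4-fluorophenyl in place of 3,4-dichlorophenyl on a saturated chain carbon bound to a nitrogen on an aromatic ring. For the measured compounds named here, no measured pair shows this change, so its size is unknown here. A modest loss in this assay is expected, though a step within the scatter cannot be ruled out. For compound 4 the estimated value is 5500 nM, with a range from 1800 nM to 17000 nM. The step this estimate means is a 1.7-fold higher number from compound 1 to compound 4 (0.23 log units; within the scatter), an expected weakening.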

Compound 4, concentration for 50% growth inhibition: 2190 nM
Compound 4: the middle estimate sits 2.5-fold (0.40 log units) above what was measured, and the stated range covers the measured number.
By their numbers in this assay, from the lowest: compounds 4 and 1 (each within the scatter of the next); then compound 2; then compound 3.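

On the benzyl arm, 4-fluorophenyl in place of 3,4-dichlorophenyl gives a 1.5-fold lower number from compound 1 to compound 4 (0.17 log units; within the scatter) in this assay. For the compounds shown here, this is the first direct reading at this position, and in this pair the two chlorines can give way to one fluorine with no change beyond the scatter. No measurement here explains why the two arms read alike.

The compounds shown leave open how an unsubstituted phenyl, a methoxy group or a carboxylic acid on this ring would read. They also leave open whether a longer chain in place of the benzyl carbon would hold the number.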